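Swapping 2-fluorophenyl for 3,4,5-trimethoxyphenyl in compound 3

A few compounds are considered here, and "the series" means these few. Any claim that something is new, unique, unknown or untested is made for them only; others in the source may bear on it.

Measured in a functional assay on QGY-7703 cells (Homo sapiens) for cytotoxicity, read by MTT assay, with a stated time of 24 h; on this read-out lower numbers stand for stronger inhibition and higher numbers for weaker inhibition:
compound 1 `COc1cc(/C=C2\CN(S(=O)(=O)c3ccc(NC(C)=O)cc3)C/C(=C\c3cc(OC)c(OC)c(OC)c3)C2=O)cc(OC)c1OC`: 1900 nM
compound 2 `COc1cc(/C=C2\CN(S(=O)(=O)c3ccc(F)cc3)C/C(=C\c3ccc(C#N)cc3)C2=O)cc(OC)c1OC`: 4980 nM
compound 3 `CC(=O)Nc1ccc(S(=O)(=O)N2C/C(=C\c3ccc(C#N)cc3)C(=O)/C(=C/c3ccccc3F)C2)cc1`: 2050 nM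

Compound 3, at 2050 nM, cannot be told apart from compound 1 at 1900 nM, since the two lie within the usual scatter of repeated measurements. Compound 2, at 4980 nM, gives a higher number than compound 3, and that gap lies beyond the scatter. Higher here means weaker inhibition.

Compound 4 `COc1cc(/C=C2\CN(S(=O)(=O)c3ccc(NC(C)=O)cc3)C/C(=C\c3ccc(C#N)cc3)C2=O)cc(OC)c1OC` is compound 3 with 3,4,5-trimethoxyphenyl in place of 2-fluorophenyl on a double-bonded chain carbon bound to a double-bonded ring carbon.

Among the measured compounds shown here, no measured pair isolates this change, so any expectation is indirect. Compound 1 also carries 3,4,5-trimethoxyphenyl and gives 1900 nM, while compound 2 carries it as well and gives 4980 nM. A small step towards a higher number in this assay, probably within the scatter, is therefore expected. The estimated change is a 1.2-fold higher number from compound 3 to compound 4 (0.09 log units; within the scatter). For compound 4 the expected value is 2500 nM, with an estimated range of 1100 nM to 5500 nM.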

Compound 4, half-maximal inhibitory concentration: 1890 nM
For compound 4 the middle estimate is 1.3-fold (0.12 log units) above the measured one; the measured number falls inside the stated range.
By their numbers in this assay, from the lowest: compounds 4, 1 and 3 (each within the scatter of the next); then compound 2.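

In this assay, placing 3,4,5-trimethoxyphenyl on a double-bonded chain carbon bound to a double-bonded ring carbon in place of 2-fluorophenyl gives a 1.1-fold lower number from compound 3 to compound 4 (0.04 log units; within the scatter) and so leaves the reading within the scatter. Placing 4-cyanophenyl there in place of 3,4,5-trimethoxyphenyl gives a 1.0-fold lower number from compound 1 to compound 4 (0.00 log units; within the scatter) and again no readable difference, so at this place all three aromatic groups fit the same level of cytotoxicity in these compounds. The one clear move comes elsewhere: acetamido in place of fluoro on an aromatic carbon gives a 2.6-fold lower number from compound 2 to compound 4 (0.42 log units; beyond the scatter) and this step lies beyond the scatter.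

Going by these compounds, whether an amine or a carboxylic acid at the double-bonded chain carbon would also leave the number in place remains open. No measurement here accounts for the flat steps or for the acetamido step.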